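This account rests on a few compounds, and the source may have more. Where it says the series, first, only, none or still open, it means among the compounds named here.

Series notes. Three compounds have numbers in a functional assay on RPMI-8226 cells (Homo sapiens) for cytotoxicity, read by sulforhodamine B assay, with a stated time of 48 h; a lower number here means a stronger inhibitor of growth, a higher number a weaker inhibitor of growth: compound 1 `ClCc1cccc(Cn2cnc3c(Cl)nc(Cl)nc32)c1` gives 3310 nM, compound 2 `Nc1nc(Cl)c2ncn(Cc3ccccc3CCl)c2n1` gives 11200 nM, and compound 3 `ClCc1ccccc1Cn1cnc2nc(Cl)nc(Cl)c21` gives 210 nM. Compound 2 stands highest of the three; compound 1 lies nearest and compound 3 furthest, both beyond the scatter. Compound 4 `ClCc1ccccc1Cn1cnc2c(Cl)ncnc21` is not yet measured. The change from compound 2 to compound 4 is hydrogen in place of amino on an aromatic carbon, on an aromatic carbon of a six-membered aromatic ring with 2 nitrogen, between two ring nitrogen atoms, meta to a chloro group. For the measured compounds named here, with no measured pair sharing this change, the expectation is a moderate downward step in this assay, larger than the scatter, since compound 3 reaches 210 nM without an amino group. Compound 4 is estimated at 1800 nM, within 400 nM to 7000 nM, an expected step of a 6.2-fold lower number from compound 2 to compound 4 (0.79 log units; beyond the scatter).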

Compound 4, concentration for 50% growth inhibition: 14100 nM
Compound 4: the middle estimate sits 7.8-fold (0.89 log units) below what was measured; the whole stated range lies below it.
By their numbers in this assay, from the lowest: compound 3; then compound 1; then compounds 2 and 4 (each within the scatter of the next).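

In this assay, the pair gives the series its first one-place comparison, and hydrogen in place of amino on this aromatic carbon, between two ring nitrogen atoms, gives a 1.3-fold higher number from compound 2 to compound 4 (0.10 log units; within the scatter). At this position, amino and hydrogen therefore cannot be told apart in this read-out. No evidence on hand accounts for this result.

On these data alone, whether a methoxy, a dimethylamino or a chloro group on this carbon would leave the number unchanged remains open. Also open, as far as these compounds go, is whether the same exchange reads alike with the chloromethyl group at another place on the benzyl ring.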